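The source may hold more compounds than are shown below. What is called first, only, known or untested is meant among the compounds shown, and "the series" means these compounds.

For the measured compounds named here, in an ADME assay on Caco-2 cells (Homo sapiens) for permeability, read by LC-MS, in the apical to basolateral direction, with a stated time of 60 min, at pH 6.5 (a lower number here means that the compound crosses the layer more slowly, a higher number that the compound crosses the layer faster), compound 2 `O=C(NCc1cc(Cl)ccc1-n1cnnn1)[C@@H]1C[C@@H]2C[C@@H]2N1C(=O)[C@H](O)Cc1ccccn1` gives 1.2 10^-6 cm/s, the lower of the two numbers so far, and compound 1 `CC(C)(C)C[C@@H](O)C(=O)N1[C@H](C(=O)NCc2cc(Cl)ccc2-n2cnnn2)C[C@@H]2C[C@@H]21` gives 25 10^-6 cm/s. Compound 3 `COC(C)(C)[C@@H](O)C(=O)N1[C@H](C(=O)NCc2cc(Cl)ccc2-n2cnnn2)C[C@@H]2C[C@@H]21` has 1-methoxy-1-methylethyl in place of (pyridin-2-yl)methyl on a saturated chain carbon bound to a carbonyl carbon and an oxygen on a saturated carbon. Going by the values given here, only one measured step bears on this change: a 21-fold lower number from compound 1 to compound 2 (1.32 log units; beyond the scatter), which is large and beyond the scatter, and which brought in pyridin-2-yl in place of tert-butyl. Compound 3, like compound 1, has no ring in this group, so a sizeable rise is expected, though one smaller than that drop. For compound 3 the estimated step is expected to be an 8.3-fold higher number from compound 2 to compound 3 (0.92 log units; beyond the scatter). The estimate for compound 3 is 10 10^-6 cm/s, within a range of 3 10^-6 cm/s to 28 10^-6 cm/s.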

Compound 3, apparent permeability: 16 10^-6 cm/s
The estimate for compound 3 lay 1.6-fold (0.20 log units) below the measured number; the measured number falls inside the stated range.
By their numbers in this assay, from the lowest: compound 2; then compounds 3 and 1 (each within the scatter of the next).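

In this assay the ring-free 1-methoxy-1-methylethyl in place of (pyridin-2-yl)methyl gives a 13-fold higher number from compound 2 to compound 3 (1.12 log units; beyond the scatter) and so shows that a second group without a ring, this one carrying an oxygen, also stands well clear of compound 2. In place of neopentyl the same group gives a 1.6-fold lower number from compound 1 to compound 3 (0.19 log units; within the scatter) and so brings no readable change. No measured evidence here explains these numbers. From the compounds shown here alone, whether a benzyl group, which has a ring but no ring nitrogen, would read as low as compound 2 stays open, as does the reading of an amine on this chain.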